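Trifluoromethyl on the aryl ring: compound 3 to compound 4

The source may hold more compounds than are shown below. What is called first, only, known or untested is meant among the compounds shown, and "the series" means these compounds.

Measured in a functional assay on MDA-MB-231 cells (Homo sapiens) for cytotoxicity, read by MTT assay, with a stated time of 48 h; on this read-out higher numbers stand for weaker inhibition and lower numbers for stronger inhibition:
compound 1 `COc1ccc(N/C=C\C(=O)c2nc(-c3ccc(F)cc3)n3ccccc23)cc1`: > 30000 nM, a limit of the assay and not a number
compound 2 `O=C(/C=C\Nc1ccc(Cl)cc1)c1nc(-c2ccc(C(F)(F)F)cc2)n2ccccc12`: 3840 nM
compound 3 `COc1ccc(N/C=C\C(=O)c2nc(-c3ccccc3)n3ccccc23)cc1`: 28300 nM

Among the two numbers, compound 3 holds the higher one; compound 2 sits well below it, and that gap lies beyond the scatter. For the measured compounds named here, the single step measured so far on the same ring, an at least 1.0-fold lower number from compound 1 to compound 3 (0.02 log units; that floor lies within the scatter), is within the scatter, so it gives no guidance on the direction of a change there.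

Compound 4 `COc1ccc(N/C=C\C(=O)c2nc(-c3ccc(C(F)(F)F)cc3)n3ccccc23)cc1` differs from compound 3 by trifluoromethyl in place of hydrogen on an aromatic carbon. Going by the values given here, no measured step carries exactly this change. Compound 2 already bears the entering trifluoromethylphenyl group, though with a different anilino part, and its value is far lower than that of compound 3. On that ground a lower number is expected for compound 4, with considerable uncertainty. Compound 4 is therefore estimated at 12000 nM, within the range 4000 nM to 30000 nM, which corresponds to an expected step of a 2.4-fold lower number from compound 3 to compound 4 (0.37 log units; beyond the scatter).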

Compound 4, half-maximal inhibitory concentration: > 30000 nM
Compound 4 gave a limit, no number; the forecaster's own chance of this, stated with the estimate: 25%; at least 2.5-fold (0.39 log units) between middle value and limit.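

In this assay compound 4 gives > 30000 nM, a limit of the assay and not a number, and this limit bounds what can be read here: the limit of > 30000 nM in this assay, at which 2 of the 4 values shown sit. Trifluoromethyl in place of hydrogen gives an at least 1.0-fold higher number from compound 3 to compound 4 (0.02 log units; that floor lies within the scatter), so with the methoxy group present the 4-(trifluoromethyl)phenyl group brings no lower number, and the low value of compound 2 does not follow from that group alone. With trifluoromethyl held fixed, methoxy in place of chloro gives an at least 7.8-fold higher number from compound 2 to compound 4 (0.89 log units; beyond the scatter), which ties that gap to the chloro and methoxy exchange, while the step between compound 1 and compound 4 cannot be read, since both values are limits.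

On these data alone, how far compound 4 lies past its limit remains unknown, so a real rise from compound 3 cannot be told from none. As far as these compounds go, whether an amine or a carboxylic acid in place of trifluoromethyl would lower the number also stays open.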